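Removing one trifluoromethyl from the weakest of three anilides

The source may report more compounds than this note shows. Statements on the series, on what has been measured and on what is new or still open speak of the compounds shown alone.

Three compounds share one core, a diaryl sulfide carrying a phenol on one ring and an amide to a substituted aniline on the other; they differ only in the trifluoromethyl groups on the aniline ring. Compound 1 `O=C(Nc1cc(C(F)(F)F)cc(C(F)(F)F)c1)c1ccc(Sc2ccc(O)cc2)cc1` carries two, and in a functional assay on LNCaP cells (Homo sapiens) for antiproliferative activity, read by fluorescence and propidium iodide staining, with a stated time of 96 h (on this read-out lower numbers stand for stronger inhibition and higher numbers for weaker inhibition), compound 1 gives 2390 nM. Compound 2 `O=C(Nc1cc(C(F)(F)F)ccc1C(F)(F)F)c1ccc(Sc2ccc(O)cc2)cc1` also carries two, placed differently, and in this assay compound 2 gives 11400 nM, the highest of the three numbers, so it is the weakest inhibitor here. Compound 3 `O=C(Nc1cccc(C(F)(F)F)c1)c1ccc(Sc2ccc(O)cc2)cc1` carries one, and in this assay compound 3 gives 9660 nM.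

Compound 4 `O=C(Nc1ccccc1C(F)(F)F)c1ccc(Sc2ccc(O)cc2)cc1` arises from compound 2 through (hydrogen in place of trifluoromethyl on an aromatic carbon). Among the compounds with values here, two measured steps bear on taking a trifluoromethyl away: a 4.0-fold higher number from compound 1 to compound 3 (0.61 log units; beyond the scatter), whereas a 1.2-fold lower number from compound 2 to compound 3 (0.07 log units; within the scatter). Neither removes the same group as the step to compound 4, and the two point in different directions, the second one within the scatter. A step no larger than the scatter therefore seems most likely, with a weak lean toward a higher number given that compound 2 already sits highest. In this assay compound 4 is expected to give 13000 nM, between 5000 nM and 32000 nM, which would mean an estimated 1.1-fold higher number from compound 2 to compound 4 (0.06 log units; within the scatter).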

Compound 4, half-maximal inhibitory concentration: 11400 nM
Estimate against measurement, compound 4: 1.1-fold (0.06 log units) above; the measured number falls inside the stated range.
By their numbers in this assay, from the lowest: compound 1; then compounds 3, 2 and 4 (each within the scatter of the next).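

In this assay, taking away the trifluoromethyl that sits meta to a large group and para to a trifluoromethyl group gives no change at the digits printed from compound 2 to compound 4 (within the scatter). On this evidence, that trifluoromethyl can be replaced by hydrogen with no visible effect on the read-out, so this position adds nothing measurable to what the rest of compound 2 already shows. The earlier steps could not show this, as neither removed this group, and the new step shows that the same exchange does not carry the same weight everywhere on the aniline ring, since its size depends on which compound it is made on: the same change on two cores in this assay, a 4.0-fold higher number (0.61 log units; beyond the scatter) from compound 1 to compound 3 and no change at the digits printed (within the scatter) from compound 2 to compound 4, 4.0-fold (0.61 log units) apart, beyond the scatter of two such steps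

Hydrogen and trifluoromethyl are the only two groups seen at this position, so it remains open whether a chlorine, a methoxy group or an amine placed there would move the number or leave it flat as well. The compounds shown also do not explain why the exchange differs between the two cores, and a single cell read-out cannot settle that question.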